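This account rests on a few compounds, and the source may have more. Where it says the series, first, only, none or still open, it means among the compounds named here.

In a functional assay on HT-29 cells (Homo sapiens) for antiproliferative activity, read by MTT assay, with a stated time of 72 h (a higher number here means a weaker inhibitor, a lower number a stronger inhibitor), compound 1 `CCn1ccnc1-c1cc(OC)c(OC)c(OC)c1` gives only a limit of the assay, > 100000 nM, as the limit of > 100000 nM in this assay, at which 1 of the 3 values shown sits, records. Compound 2 `COc1cc(-c2nccn2-c2ccc3sccc3c2)cc(OC)c1OC` gives 1500 nM in this assay, and compound 3 `COc1cc(-c2nccn2-c2ccc3[nH]ccc3c2)cc(OC)c1OC` gives 9100 nM; each of these carries an aromatic group on the aromatic nitrogen of the five-membered aromatic ring with 2 nitrogen, where compound 1 carries ethyl. Compound 4 `COc1cc(-c2nccn2-c2ccc(F)cc2)cc(OC)c1OC` has not yet been measured. The change from compound 1 to compound 4 is 4-fluorophenyl in place of ethyl on an aromatic nitrogen. For the measured compounds named here, no step between two measured compounds is known here, so the expectation rests on the values of compound 2 and compound 3. A large step toward stronger inhibition is expected, an at least 20-fold lower number from compound 1 to compound 4 (1.30 log units; beyond the scatter). Compound 4 is expected to give 5000 nM, within 1200 nM to 30000 nM.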

Compound 4, half-maximal inhibitory concentration: 29300 nM
Compound 4: middle estimate off by 5.9-fold (0.77 log units), on the low side; the range from low to high includes it.
By their numbers in this assay, from the lowest: compound 2; then compound 3; then compound 4. At a limit, above all of these: compound 1.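

Putting 4-fluorophenyl in place of ethyl on the aromatic nitrogen gives an at least 3.4-fold lower number from compound 1 to compound 4 (0.53 log units; beyond the scatter) in this assay, so a single substituted phenyl here is enough to give a measured value. Compound 4, at 29300 nM, still has a higher number than compound 3, at 9100 nM, and compound 2, at 1500 nM, so the aromatic groups at this position are not interchangeable. The step gives only a minimum size, since compound 1 stands at a limit of the assay: the limit of > 100000 nM in this assay, at which 1 of the 4 values shown sits.

Still open, on these data alone, is how plain phenyl, or phenyl carrying methoxy or an amine instead of fluorine, would compare with compound 4. Also open, as far as these compounds go, is whether a longer chain in place of ethyl would give a measurable value.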